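Acetyl to methoxycarbonyl on the sulfone series

The source may hold more compounds than are shown below. What is called first, only, known or untested is meant among the compounds shown, and "the series" means these compounds.

Of the compounds shown here, three have been measured in a functional assay on MT4 cells (Homo sapiens) for antiproliferative activity, read by MTT assay, with a stated time of 96 h; on this read-out lower numbers stand for an effect already at smaller amounts and higher numbers for an effect only at larger amounts of compound. Compound 1 `Cn1cc(/C=C(\C#N)S(C)(=O)=O)c2ccccc21` reaches only the limit of the assay, > 100000 nM, which is not a number (the limit of > 100000 nM in this assay, at which 1 of the 3 values shown sits). Compound 2 `CCOC(=O)C(=Cc1c(-c2ccccc2)[nH]c2ccccc12)C(=O)OCC` gives 2300 nM. Compound 3 `CC(=O)/C(=C\c1c(-c2ccccc2)[nH]c2ccccc12)S(=O)(=O)c1ccccc1` gives 400 nM, the lowest of the two numbers shown, and its gap to compound 2 lies beyond the scatter. Compound 4 `COC(=O)/C(=C\c1c(-c2ccccc2)[nH]c2ccccc12)S(=O)(=O)c1ccccc1` is not yet measured; it differs from compound 3 by methoxy in place of methyl on a carbonyl carbon, that is, acetyl to methoxycarbonyl. Among the measured compounds shown here, no measured pair follows this change, so only an expectation can be given. The step expected in this assay, a 1.8-fold higher number from compound 3 to compound 4 (0.24 log units; within the scatter), is small, toward higher numbers if anything, hardly beyond the scatter. Compound 4 is therefore expected to give 700 nM, within 200 nM to 2500 nM.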

Compound 4, half-maximal effective concentration: 1000 nM
For compound 4 the middle estimate is 1.4-fold (0.15 log units) below the measured one; the range from low to high includes it.
By their numbers in this assay, from the lowest: compound 3; then compound 4; then compound 2. At a limit, above all of these: compound 1.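

In this assay this carbonyl carbon responds to a small change: methoxy in place of methyl gives a 2.5-fold higher number from compound 3 to compound 4 (0.40 log units; beyond the scatter). Among the compounds shown here, this is the first step that can be read at a single place, and it favours acetyl over methoxycarbonyl, though on this one pair only. Nothing measured here bears on the reason for the step. Going by these compounds, whether an amide or a carboxylic acid on this carbonyl carbon would give a lower or a higher number remains open. Also open, on these data alone, is whether the step holds with a methyl sulfone in place of the phenyl sulfone.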